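The source may hold more compounds than are shown below. What is called first, only, known or untested is meant among the compounds shown, and "the series" means these compounds.

Compound 1 `O=S(=O)(c1ccccc1)c1nc2ccccc2nc1N1CCCC1` — 20800 nM in a functional assay on PC-3 cells (Homo sapiens) for cytotoxicity, read by MTT assay, with a stated time of 72 h; a lower number here means a stronger inhibitor, a higher number a weaker inhibitor. Compound 2 `O=S(=O)(c1ccccc1)c1nc2ccccc2nc1N1CCCC(O)C1` — 2100 nM in this assay. Compound 3 `O=S(=O)(c1ccc(Br)cc1)c1nc2ccccc2nc1N1CCCC(O)C1` — 3690 nM in this assay.

Compound 2 gives the lowest number of the three; its gap to compound 3 is a 1.8-fold higher number from compound 2 to compound 3 (0.24 log units; within the scatter), within the scatter, while the step of a 9.9-fold lower number from compound 1 to compound 2 (1.00 log units; beyond the scatter) lies beyond it. Compound 4 `O=S(=O)(c1ccccc1)c1nc2ccccc2nc1N1CCC(O)CC1` differs from compound 2 by 4-hydroxypiperidin-1-yl in place of 3-hydroxypiperidin-1-yl on an aromatic carbon. Within the data shown here, no measured step moves the hydroxyl within the ring: the step of a 9.9-fold lower number from compound 1 to compound 2 (1.00 log units; beyond the scatter) changed the ring itself, and a 1.8-fold higher number from compound 2 to compound 3 (0.24 log units; within the scatter) touched the other end. The change is therefore expected to give no step beyond the scatter in this assay, estimated at a 1.2-fold higher number from compound 2 to compound 4 (0.08 log units; within the scatter). Compound 4 is expected at 2500 nM, between 800 nM and 8000 nM.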

Compound 4, half-maximal inhibitory concentration: 4980 nM
Compound 4: the middle estimate sits 2.0-fold (0.30 log units) below what was measured; the range from low to high includes it.
By their numbers in this assay, from the lowest: compounds 2, 3 and 4 (each within the scatter of the next, the first and the last beyond it); then compound 1.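

Exchanging 3-hydroxypiperidin-1-yl for 4-hydroxypiperidin-1-yl, with the atoms unchanged, is not a silent change at this position in this assay (a 2.4-fold higher number from compound 2 to compound 4 (0.38 log units; beyond the scatter)). The lower number relative to pyrrolidin-1-yl also survives with the 4-hydroxypiperidin-1-yl group (a 4.2-fold lower number from compound 1 to compound 4 (0.62 log units; beyond the scatter)), so it is not confined to 3-hydroxypiperidin-1-yl. Nothing available explains the difference between these two groups.

The compounds shown leave open where an unsubstituted piperidine, an aminopiperidine or a piperidine carboxylic acid would fall at this position. They also leave open whether bromo would have the same outcome alongside 4-hydroxypiperidin-1-yl.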